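From amino to nitro at the limit of the assay

The compounds below may be only part of what the source reports. "The series", "measured", "known", "first", "only" and "open" are said of these compounds alone.

Compound 1 `COc1ccc(-c2cn(Cc3cc(OC)c(OC)c(OC)c3)nn2)cc1` gives > 10000 nM
Compound 2 `COc1ccc(-c2cn(Cc3cc(OC)c(OC)c(OC)c3)nn2)cc1Br` gives > 10000 nM
Compound 3 `COc1ccc(-c2cn(Cc3cc(OC)c(OC)c(OC)c3)nn2)cc1N` gives > 10000 nM

In a functional assay on K562 cells (Homo sapiens) for cytotoxicity, read by MTT assay, with a stated time of 5 days (on this read-out lower numbers stand for stronger inhibition and higher numbers for weaker inhibition), compound 3 gives > 10000 nM as a limit and not a number. Going by the values given here, the series so far shows the limit of > 10000 nM in this assay, at which 3 of the 3 values shown sit, so each value is a limit. Compound 4 `COc1ccc(-c2cn(Cc3cc(OC)c(OC)c(OC)c3)nn2)cc1[N+](=O)[O-]` differs by nitro in place of amino on an aromatic carbon. Among the compounds with values here, three measured steps bear on this change: a step that the two limits leave unreadable from compound 1 to compound 2 and a step that the two limits leave unreadable from compound 1 to compound 3 and a step that the two limits leave unreadable from compound 2 to compound 3 all remain without a readable size. They support no direction, so no change beyond the scatter is expected in this assay here. The expected move is a step that the limit leaves unreadable from compound 3 to compound 4 on this reckoning. For compound 4 the estimate is 12000 nM with an expected range from 3000 nM to 40000 nM and a report as a limit is likely.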

Compound 4, half-maximal inhibitory concentration: > 10000 nM
Compound 4 was reported as a limit; the forecaster's own chance of this, stated with the estimate: 85%; the middle value does not contradict the limit.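

In this assay compound 4 gives > 10000 nM, a limit and not a number, so its steps from compound 1, compound 2 and compound 3 cannot be read. The compounds shown leave open how these four compare with one another in this assay: the limit of > 10000 nM in this assay, at which 4 of the 4 values shown sit.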